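The compounds below may be only part of what the source reports. "The series", "measured", "known", "first", "only" and "open" are said of these compounds alone.

Three compounds share one core, each bearing a cinnamamide-type chain on an aromatic amine. Compound 1 `COc1cccc(/C=C/C(=O)Nc2cc(OC)c(OC)c(OC)c2)c1` gives 12300 nM in a functional assay on HeLa cells (Homo sapiens) for cytotoxicity, read by MTT assay, with a stated time of 72 h; on this read-out lower numbers stand for stronger inhibition and higher numbers for weaker inhibition. Compound 2 `COc1ccc(/C=C/C(=O)Nc2cc(C(=O)c3cc(OC)c(OC)c(OC)c3)ccc2OC)cc1` gives 10700 nM in this assay, and compound 3 `COc1cccc(/C=C/C(=O)Nc2cc(C(=O)c3cc(OC)c(OC)c(OC)c3)ccc2OC)c1` gives 3100 nM. Compound 3 thus stands at the lowest number of the three, with compound 2 nearest and compound 1 furthest, both steps beyond the scatter. The single one-place step among these three is a 3.5-fold lower number from compound 2 to compound 3 (0.54 log units; beyond the scatter).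

Compound 4 `COc1ccc(C(=O)c2cc(OC)c(OC)c(OC)c2)cc1NC(=O)/C=C/c1ccc(C(F)(F)F)cc1` differs from compound 3 in one place: 4-(trifluoromethyl)phenyl in place of 3-methoxyphenyl on a double-bonded chain carbon bound to a double-bonded chain carbon. Among the measured compounds shown here, no measured step carries a trifluoromethyl group, so the only bearing comes from compound 2 and compound 3, where moving the methoxy group from the 4-position to the 3-position of the phenyl ring gave the step just described. Compound 4 reverts to a 4-substituted phenyl, yet with a group for which no comparison exists here. The expectation is therefore a step of a 2.6-fold higher number from compound 3 to compound 4 (0.41 log units; beyond the scatter), drifting back toward the number of compound 2, with wide uncertainty. Compound 4 is estimated at 8000 nM, within a range from 2500 nM to 25000 nM.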

Compound 4, half-maximal inhibitory concentration: 90 nM
The estimate for compound 4 lay 89-fold (1.95 log units) above the measured number; the whole stated range lies above it.
By their numbers in this assay, from the lowest: compound 4; then compound 3; then compounds 2 and 1 (each within the scatter of the next).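

Among the compounds shown here, the aromatic ring on the double-bonded chain carbon turns out to matter far more in this assay than the earlier compounds suggested: the methoxy shift gave only a 3.5-fold lower number from compound 2 to compound 3 (0.54 log units; beyond the scatter) and was modest, while the exchange of 3-methoxyphenyl for 4-(trifluoromethyl)phenyl gives a 34-fold lower number from compound 3 to compound 4 (1.54 log units; beyond the scatter) and is large. The comparison with compound 2 shows that the group itself carries much of this effect, since trifluoromethyl in place of methoxy on an aromatic carbon gives a 120-fold lower number from compound 2 to compound 4 (2.08 log units; beyond the scatter) and moves the number far beyond anything the methoxy pair reached. No measured evidence is available to explain why this exchange has so large an effect.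

For the compounds shown here, with only one trifluoromethyl compound in hand, it remains open whether other groups on the same phenyl ring, such as chlorine, a nitrile or a methyl group, would lower the number to a similar degree. Going by these compounds, it is also open whether a trifluoromethyl group would produce a comparable step on the core of compound 1, which lacks the carbonyl-linked ring of the other three compounds.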